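Pyrimidin-5-yl for pyridin-3-yl: cytotoxicity outlook

The source may report more compounds than this note shows. Statements on the series, on what has been measured and on what is new or still open speak of the compounds shown alone.

In an ADME assay on BV-2 cells (Mus musculus) for cytotoxicity, with a stated time of 24 h, tested at 50 uM (a higher number here means a weaker effect of the compound at the concentration tested, a lower number a stronger effect), compound 2 `COc1cccc(S(=O)(=O)/C=C/c2cccnc2)c1` gives 90.8%, the highest of the three numbers in hand. Among the measured compounds shown here, compound 1 `COc1cccc(S(=O)(=O)/C=C/c2cccc(Cl)n2)c1` at 89.3% sits within the scatter of it, while compound 3 `COc1cccc(S(=O)(=O)/C=C/c2cccnc2Cl)c1` at 78.8% lies beyond it; the one single-point step measured, a number 12 percentage points lower from compound 2 to compound 3 (beyond the scatter), follows a chloro in place of hydrogen on an aromatic carbon. Compound 4 `COc1cccc(S(=O)(=O)/C=C/c2cncnc2)c1` differs from compound 2 by pyrimidin-5-yl in place of pyridin-3-yl on a double-bonded chain carbon bound to a double-bonded chain carbon. For the measured compounds named here, no measured step exchanges a ring atom in this way, so the chloro step offers no direct guide, and in the absence of such a precedent the expectation is a step of no size beyond the scatter. For compound 4 the expected value in this assay is 88%, within 75% to 98%. This amounts to an expected step of a number 2.8 percentage points lower from compound 2 to compound 4 (within the scatter).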

Compound 4, a percentage reported as activity, at one concentration (the size of the read-out at that concentration, not a potency): 100%
Compound 4: the middle estimate sits 12 percentage points below what was measured; the measured number lies above the stated range.
By their numbers in this assay, from the lowest: compound 3; then compounds 1, 2 and 4 (each within the scatter of the next, the first and the last beyond it).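

In this assay, the exchange of pyridin-3-yl for pyrimidin-5-yl on the double-bonded chain carbon gives a number 9.2 percentage points higher from compound 2 to compound 4 (within the scatter), so this first ring-atom change at the position produces no step beyond the scatter. Among the single-place steps, only the chloro step remains beyond it, at a number 12 percentage points lower from compound 2 to compound 3 (beyond the scatter). No available evidence bears on this result.

On these data alone, whether chloro on the pyrimidin-5-yl ring would give a step like the one on pyridin-3-yl remains open. So does the effect of an amine on that ring.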